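Chloro in place of methoxy, read across two cores

A few compounds are considered here, and "the series" means these few. Any claim that something is new, unique, unknown or untested is made for them only; others in the source may bear on it.

Compound 1 `COc1ccccc1N1CCN(CCCCCCn2nc(-n3cnc4ccccc43)ccc2=O)CC1` gives 6.4 nM in an assay on cell membranes from brain for binding affinity to Adrenergic receptor alpha-1 (Rattus norvegicus), read by radioligand binding; on this read-out higher numbers stand for weaker inhibition and lower numbers for stronger inhibition. Compound 2 `O=c1ccc(-n2cnc3ccccc32)nn1CCCCCCN1CCN(c2ccccc2Cl)CC1` carries the change chloro in place of methoxy on an aromatic carbon and in this assay compound 2 gives 15.1 nM; the step of a 2.4-fold higher number from compound 1 to compound 2 (0.37 log units; beyond the scatter) is modest but beyond the scatter. Compound 3 `COc1ccccc1N1CCN(CCn2nc(-n3ccnc3)ccc2=O)CC1` rests on a second core; the difference between the two cores is not broken down here. In this assay compound 3 gives 237 nM, the highest number of the three measured, with compound 2 the nearest and compound 1 the furthest.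

Compound 4 `O=c1ccc(-n2ccnc2)nn1CCN1CCN(c2ccccc2Cl)CC1` is not yet measured. It differs from compound 3 by chloro in place of methoxy on an aromatic carbon, the same change already seen between compound 1 and compound 2, with the place described in the same words in both cases; the change occurs twice among the compounds shown. Among the measured compounds shown here, only one measured pair exists for it, so whether the step carries from one core to the other is open.

Compound 4 is expected to give about 550 nM in this assay, with a range from 200 nM to 1500 nM. For the measured compounds named here, that expectation rests on the single measured instance a 2.4-fold higher number from compound 1 to compound 2 (0.37 log units; beyond the scatter), read onto the number for compound 3. The expected step of a 2.3-fold higher number from compound 3 to compound 4 (0.37 log units; beyond the scatter) is estimated to match the earlier one in size, while the wide range allows that the second core need not answer the same change in the same way.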

Compound 4, inhibition constant: 472 nM
Compound 4: middle estimate off by 1.2-fold (0.07 log units), on the high side; low and high end bracket the measured number.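

In this assay the change chloro in place of methoxy on the core of compound 3 gives a 2.0-fold higher number from compound 3 to compound 4 (0.30 log units; within the scatter) and so, taken alone, cannot be told apart from repeat measurement. Set beside the step on the core of compound 1, it reads as a step of the same size: the same change on two cores in this assay, a 2.4-fold higher number (0.37 log units; beyond the scatter) from compound 1 to compound 2 and a 2.0-fold higher number (0.30 log units; within the scatter) from compound 3 to compound 4, 1.2-fold (0.07 log units) apart, within the scatter of two such steps

Between these two cores, then, the change from 2-methoxyphenyl to 2-chlorophenyl carries over as a small step of similar size, but the reading rests on a single pair for each core, and one of the two steps does not clear the scatter on its own, so it does not show that the change would act alike on any further core, nor does it give a reason for the match.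

The two cores differ in more than one place, so the compounds shown leave open which part of that difference goes with the much higher numbers on the core of compound 3, a question that the core of compound 3 carrying a longer chain would address directly. Also open, on these data alone, is whether other groups in the same place, such as fluoro, methyl or trifluoromethyl, would keep the same size of step on both cores.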